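A few compounds are considered here, and "the series" means these few. Any claim that something is new, unique, unknown or untested is made for them only; others in the source may bear on it.

Compound 1 `NC(=S)N1N=C(c2ccc(N3CCCCC3)cc2)CC1c1ccc(Cl)cc1` in a functional assay on A-375 cells (Homo sapiens) for antiproliferative activity, read by MTT assay, with a stated time of 72 h (on this read-out higher numbers stand for weaker inhibition and lower numbers for stronger inhibition), gives > 100000 nM, which is a limit of the assay and not a number. Compound 2 `Clc1ccc(C2CC(c3ccc(N4CCCCC4)cc3)=NN2c2nc(-c3ccccc3)cs2)cc1` in this assay gives 65800 nM. Compound 3 `FC(F)(F)c1ccc(-c2csc(N3N=C(c4ccc(N5CCCCC5)cc4)CC3c3ccc(Cl)cc3)n2)cc1` in this assay gives 64200 nM.

Among the two compounds with a number, compound 3 and compound 2 lie within the scatter of each other: the step of a 1.0-fold lower number from compound 2 to compound 3 (0.01 log units; within the scatter) is too small to count as a change, and compound 1 contributes only its limit (the limit of > 100000 nM in this assay, at which 1 of the 3 values shown sits).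

Compound 4 `Cc1ccc(-c2csc(N3N=C(c4ccc(N5CCCCC5)cc4)CC3c3ccc(Cl)cc3)n2)cc1` is not yet measured. It differs from compound 3 by methyl in place of trifluoromethyl on an aromatic carbon. Among the compounds with values here, the one measured step at this position, a 1.0-fold lower number from compound 2 to compound 3 (0.01 log units; within the scatter), moved trifluoromethyl onto a bare aromatic carbon without a change beyond the scatter. The other step, an at least 1.5-fold lower number from compound 1 to compound 2 (0.18 log units; that floor lies within the scatter), alters a distant part of the shared core and starts from a limit, so it says little about this position. Trading trifluoromethyl for methyl on the same carbon is therefore expected to give no step beyond the scatter, and the step of a 1.0-fold higher number from compound 3 to compound 4 (0.01 log units; within the scatter) is the estimate that follows. Compound 4 is expected to give 65000 nM in this assay, with a range from 30000 nM to 130000 nM.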

Compound 4, half-maximal inhibitory concentration: > 100000 nM
Compound 4 was reported as a limit; the forecaster's own chance of this, stated with the estimate: 20%; middle value at least 1.5-fold (0.18 log units) from the limit.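

Going from 4-(trifluoromethyl)phenyl to 4-methylphenyl gives an at least 1.5-fold higher number from compound 3 to compound 4 (0.19 log units; that floor lies within the scatter), and methyl in place of hydrogen on the same carbon gives an at least 1.5-fold higher number from compound 2 to compound 4 (0.18 log units; that floor lies within the scatter). Within the data shown here, both are only floors that lie within the scatter, so neither proves a change, but the earlier swap of hydrogen for trifluoromethyl stayed within the scatter too, and methyl is the first group at this position to leave a compound with no number in this assay. The result for compound 4 is a limit and not a number, and the step from compound 1 to compound 4 cannot be read, as both ends are limits: the limit of > 100000 nM in this assay, at which 2 of the 4 values shown sit.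

The compounds shown leave open how large the true gap is between compound 4 and the two compounds with numbers, and so whether this small swap on the ring matters at all. They also leave open what other groups on this carbon would do, such as a methoxy group, an amine or a carboxylic acid, and whether any of them would give a number clearly lower than those of compound 2 and compound 3.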